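Changing the amine group of compound 3

A few compounds are considered here, and "the series" means these few. Any claim that something is new, unique, unknown or untested is made for them only; others in the source may bear on it.

Values in a functional assay on HepG2 cells (Homo sapiens) for inhibition, read by MTT assay, with a stated time of 3 days (a lower number here means a stronger inhibitor, a higher number a weaker inhibitor), for the three measured compounds:
- compound 1 `COc1cc(-c2nc3ccccc3s2)ccc1OCC(=O)NNC(=O)CN(C(C)=O)[C@@H](CS)C(=O)O` gives 3420 nM
- compound 2 `COc1cc(-c2nc3ccccc3s2)ccc1OCC(=O)NNC(=O)CN[C@@H](CS(=O)(=O)O)C(=O)O` gives 3690 nM
- compound 3 `CCOC(=O)[C@H](NCC(=O)NNC(=O)COc1ccc(-c2nc3ccccc3s2)cc1OC)[C@@H](C)CC` gives 3970 nM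

Compound 3, at 3970 nM in this assay, lies within the scatter of compound 1 and compound 2, so the three cannot be ranked. The next molecule, compound 4 `CCOC(=O)[C@H](CS)NCC(=O)NNC(=O)COc1ccc(-c2nc3ccccc3s2)cc1OC`, keeps the shared core and differs from compound 3 at one place, an amine nitrogen. There, 1-(ethoxycarbonyl)-2-sulfanylethyl stands in place of 1-(ethoxycarbonyl)-2-methylbutyl (1-(ethoxycarbonyl)-2-sulfanylethyl in place of 1-(ethoxycarbonyl)-2-methylbutyl on an amine nitrogen).

For the measured compounds named here, three measured steps bear on this change. Exchanging the group on the same amine nitrogen gave a 1.1-fold higher number from compound 2 to compound 3 (0.03 log units; within the scatter), and the wider exchanges in this part of the molecule gave a 1.2-fold higher number from compound 1 to compound 3 (0.06 log units; within the scatter) and a 1.1-fold higher number from compound 1 to compound 2 (0.03 log units; within the scatter). None of them left the scatter, although the groups involved differ considerably. Going by the values given here, no measured compound carries the exact group that enters here, and three compounds are a thin basis for any expectation.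

In this assay the expected change is therefore none beyond the scatter, with no direction favoured, and the estimated step is a 1.0-fold lower number from compound 3 to compound 4 (0.02 log units; within the scatter) for now. For compound 4 the expected value is 3800 nM, with an estimated range of 1800 nM to 7500 nM as the likely span.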

Compound 4, half-maximal inhibitory concentration: 3760 nM
Estimate against measurement, compound 4: 1.0-fold (0.00 log units) above; measured number inside the range.
By their numbers in this assay, from the lowest: compounds 1, 2, 4 and 3 (each within the scatter of the next).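

In this assay, putting 1-(ethoxycarbonyl)-2-sulfanylethyl on the amine nitrogen in place of 1-(ethoxycarbonyl)-2-methylbutyl gives a 1.1-fold lower number from compound 3 to compound 4 (0.02 log units; within the scatter). A smaller group that brings in sulfur and a hydrogen-bond donor absent from the group it replaces therefore leaves the reading within the scatter. The entering group also stays level with the substituents of the other two compounds, with a 1.0-fold higher number from compound 2 to compound 4 (0.01 log units; within the scatter) and a 1.1-fold higher number from compound 1 to compound 4 (0.04 log units; within the scatter), so all four compounds, whether they carry a sulfanyl or sulfo group and a free carboxylic acid or an ethyl ester, remain unranked in this assay. No accompanying measurement offers an explanation for these readings.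

Every substituent shown here keeps a carboxylic acid or ethyl ester on the carbon bound to the nitrogen, so it remains open whether a plain benzyl group or a longer chain ending in an amine would also stay within the scatter. Also open, from the compounds shown here alone, is what a free carboxylic acid would do in place of the ethyl ester of compound 4 with the sulfanyl kept and no acetyl on the nitrogen.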